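The source may report more compounds than this note shows. Statements on the series, on what has been measured and on what is new or still open speak of the compounds shown alone.

In a functional assay on A549 cells (Homo sapiens) for antiproliferative activity, read by MTT assay, with a stated time of 24 h (a higher number here means a weaker inhibitor, a lower number a stronger inhibitor), compound 1 (`C=CCc1cc(-c2ccc(F)cc2)ccc1O`) gives > 100000 nM as a limit of the assay and not as a number. Compound 2 (`C=CCc1cc(-c2ccc(C(F)(F)F)cc2)ccc1OC`) also gives > 100000 nM as a limit and has no number of its own. The record so far is thus the limit of > 100000 nM in this assay, at which 2 of the 2 values shown sit, and nothing more. Compound 3 (`C=CCc1cc(-c2ccc(C(F)(F)F)cc2)ccc1O`) is reached from compound 2 by a single change (hydrogen in place of methyl on an oxygen on an aromatic ring), hydrogen in place of methyl on an oxygen on an aromatic ring, or methoxy to hydroxy. Compound 1 already carries a hydroxy and still gives > 100000 nM as a limit, so little gain is expected. The expected step (an at least 1.2-fold lower number from compound 2 to compound 3 (0.09 log units; that floor lies within the scatter)) is none beyond the scatter, and any real shift would most likely be toward a stronger inhibitor. Compound 3 is estimated at 80000 nM with an expected range from 30000 nM to 150000 nM in this assay and may well report only a limit.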

Compound 3, half-maximal inhibitory concentration: 76000 nM
Compound 3: the middle estimate sits 1.1-fold (0.02 log units) above what was measured; low and high end bracket the measured number.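

In this assay, going by these compounds alone, compound 3 is the only one of the three compounds with a number rather than a limit, and the other two stand at that limit: the limit of > 100000 nM in this assay, at which 2 of the 3 values shown sit. Hydrogen in place of methyl on the oxygen on the aromatic ring gives an at least 1.3-fold lower number from compound 2 to compound 3 (0.11 log units; that floor lies within the scatter), and trifluoromethyl in place of fluoro on the aromatic carbon gives an at least 1.3-fold lower number from compound 1 to compound 3 (0.11 log units; that floor lies within the scatter). Both steps are floors only, and neither floor goes beyond the scatter, so neither change is shown to have a real effect on its own.

On these data alone, the true size of either step stays open, as compound 1 and compound 2 have no number of their own. Also open, as far as these compounds go, is whether a carboxylic acid in place of the trifluoromethyl, or a longer chain in place of the methyl on that oxygen, would give a lower number.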